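Three Limits and a Fourth Compound at the Same Carbonyl

The source may report more compounds than this note shows. Statements on the series, on what has been measured and on what is new or still open speak of the compounds shown alone.

Of the compounds shown here, three have been measured in an ADME assay on Vero cells (Chlorocebus sabaeus) for cytotoxicity, read by resazurin assay, with a stated time of 3 days; a lower number here means a stronger inhibitor, a higher number a weaker inhibitor.
Compound 1, `CCOCCOC(=O)Nc1cc2nc(C3CCCCC3)[nH]c2cc1N(C)C`, gives > 100 ug/mL, which is a limit of the assay.
Compound 2, `CN(C)c1cc2[nH]c(C3CCCCC3)nc2cc1NC(=O)c1ccc(C(C)(C)C)cc1`, gives > 100 ug/mL, again a limit of the assay.
Compound 3, `CCCCNC(=O)Nc1cc2nc(C3CCCCC3)[nH]c2cc1N(C)C`, gives > 100 ug/mL, also a limit of the assay.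

Compound 3 therefore stands at the same limit as the other two, and no ranking among the three is possible, as the limit of > 100 ug/mL in this assay, at which 3 of the 3 values shown sit, records. The three steps among them, a step that the two limits leave unreadable from compound 1 to compound 2, a step that the two limits leave unreadable from compound 1 to compound 3 and a step that the two limits leave unreadable from compound 2 to compound 3, are all left unreadable by the limits, so their sizes cannot be stated.

Compound 4, `CN(C)c1cc2[nH]c(C3CCCCC3)nc2cc1NC(=O)c1ccc(F)cc1`, differs from compound 3 in one place: 4-fluorophenyl in place of butylamino on a carbonyl carbon. The step that bears most directly on it is a step that the two limits leave unreadable from compound 2 to compound 3, which exchanges another aryl group for the same butylamino group at the same carbonyl carbon and was itself unreadable; a step that the two limits leave unreadable from compound 1 to compound 2, which introduces an aryl group at that carbon, was unreadable too. On this basis no step beyond the scatter is expected in this assay, and the step from compound 3 to compound 4 is estimated as a step that the limit leaves unreadable from compound 3 to compound 4. Compound 4 is expected to give about 150 ug/mL, within a range of 60 ug/mL to 400 ug/mL, most likely reported again as a limit.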

Compound 4, half-maximal inhibitory concentration: > 100 ug/mL
Compound 4 gave a limit, no number; the forecaster's own chance of this, stated with the estimate: 85%; the middle value lies beyond the limit too.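

In this assay compound 4 gives > 100 ug/mL, which is a limit of the assay. No new step can be read between compound 4 and compound 1, compound 2 or compound 3, as all four sit at the same limit: the limit of > 100 ug/mL in this assay, at which 4 of the 4 values shown sit.

The compounds shown leave open whether the groups on the carbonyl carbon differ at all in cytotoxicity.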